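Iodo in Place of Phenyl on a Nucleoside Core

The source may report more compounds than this note shows. Statements on the series, on what has been measured and on what is new or still open speak of the compounds shown alone.

Compound 2 `COc1ncnc2c1c(-c1ccccc1)cn2[C@@H]1O[C@H](CO)[C@@H](O)[C@H]1O` stands at the limit of an ADME assay on BJ cells (Homo sapiens), read by MTT assay, with a stated time of 72 h; a higher number here means a weaker inhibitor, a lower number a stronger inhibitor: compound 2 gives > 100000 nM, a limit rather than a number. Going by the values given here, compound 1 `COc1ncnc2c1c(-c1ccoc1)cn2[C@@H]1O[C@H](CO)[C@@H](O)[C@H]1O` gives 28800 nM in this assay, so the one measured step is an at least 3.4-fold higher number from compound 1 to compound 2 (0.54 log units; beyond the scatter). Compound 3 `COc1ncnc2c1c(I)cn2[C@@H]1O[C@H](CO)[C@@H](O)[C@H]1O` arises from compound 2 by iodo in place of phenyl on an aromatic carbon. Among the compounds with values here, no measured step trades an aromatic ring for a halogen, so that single step gives only loose guidance. Because compound 2 is known only as the limit (the limit of > 100000 nM in this assay, at which 1 of the 2 values shown sits), the step is expected to be an at least 1.6-fold lower number from compound 2 to compound 3 (0.22 log units; that floor lies within the scatter). Compound 3 is estimated at 60000 nM, within 15000 nM to 300000 nM.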

Compound 3, half-maximal inhibitory concentration: 91000 nM
Compound 3: the middle estimate sits 1.5-fold (0.18 log units) below what was measured; measured number inside the range.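

In this assay, a single iodine atom at this aromatic carbon gives a 3.2-fold higher number from compound 1 to compound 3 (0.50 log units; beyond the scatter), so furan-3-yl is now set apart from a halogen as well as from another aromatic ring. Compound 1 holds the lowest number of the three, with both of its steps beyond the scatter. The step of an at least 1.0-fold lower number from compound 2 to compound 3 (0.04 log units; that floor lies within the scatter) sets no order between iodo and phenyl, because it rests on a limit: the limit of > 100000 nM in this assay, at which 1 of the 3 values shown sits.

The compounds shown leave open whether this lower number is particular to furan-3-yl or would also appear with thiophen-3-yl, an amine or a nitrile at this carbon.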